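Ethoxy for Acetamido on the Triazole Aryl Group

A few compounds are considered here, and "the series" means these few. Any claim that something is new, unique, unknown or untested is made for them only; others in the source may bear on it.

Two analogues sharing one core have been tested. Compound 1 `CCc1ccccc1-n1nncc1CN1C(=O)C2(C(C#N)=C(N)Oc3c(N)cc4nc5ccccc5nc4c32)c2ccccc21` carries a 2-ethylphenyl on the triazole nitrogen, and in a functional assay on MCF7 cells (Homo sapiens) for antiproliferative activity, read by MTT assay, with a stated time of 48 h (a higher number here means a weaker inhibitor, a lower number a stronger inhibitor), compound 1 gives 24600 nM. Compound 2 `CC(=O)Nc1ccc(-n2nncc2CN2C(=O)C3(C(C#N)=C(N)Oc4c(N)cc5nc6ccccc6nc5c43)c3ccccc32)cc1` carries a 4-acetamidophenyl instead. In this assay compound 2 reaches only the limit > 50000 nM, so no number is known for it; this is the limit of > 50000 nM in this assay, at which 1 of the 2 values shown sits. The step of an at least 2.0-fold higher number from compound 1 to compound 2 (0.30 log units; that floor lies within the scatter) is the only measured one, and it swaps the whole aryl group at once. Compound 3 `CCOc1ccc(-n2nncc2CN2C(=O)C3(C(C#N)=C(N)Oc4c(N)cc5nc6ccccc6nc5c43)c3ccccc32)cc1` differs from compound 2 in one place: ethoxy in place of acetamido on an aromatic carbon. Within the data shown here, no measured step isolates this change, so the expectation rests on compound 2 sitting at a limit and compound 1 being weak. Compound 3 is expected near 40000 nM, between 12000 nM and 120000 nM, a step of an at least 1.2-fold lower number from compound 2 to compound 3 (0.09 log units; that floor lies within the scatter) that is itself uncertain.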

Compound 3, half-maximal inhibitory concentration: 26800 nM
The estimate for compound 3 lay 1.5-fold (0.17 log units) above the measured number; low and high end bracket the measured number.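

In this assay, ethoxy in place of acetamido gives an at least 1.8-fold lower number from compound 2 to compound 3 (0.27 log units; that floor lies within the scatter), so this change on the aromatic carbon turns a result with no exact number into a measured one. Among these compounds, compound 2 has only a limit, not a number: the limit of > 50000 nM in this assay, at which 1 of the 3 values shown sits. The new compound also gives the first comparison of two aryl groups with numbers on both sides, a 1.1-fold higher number from compound 1 to compound 3 (0.04 log units; within the scatter), which means that 4-ethoxyphenyl and 2-ethylphenyl on the triazole nitrogen cannot be told apart in this assay.

From the compounds shown here alone, it remains open how large the true gap between the acetamido and ethoxy compounds is, since only its floor is known. Also open, going by these compounds, is whether an amine, a carboxylic acid or a longer alkoxy chain such as butoxy on the same carbon would move the number beyond the scatter.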